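A few compounds are considered here, and "the series" means these few. Any claim that something is new, unique, unknown or untested is made for them only; others in the source may bear on it.

Compound 1 `CN(C(=O)c1ccc(Br)cc1)c1ccc2[nH]c(-c3n[nH]c4ccccc34)cc2n1` gives 1780 nM in a functional assay on KB cells (Homo sapiens) for antiproliferative activity, read by MTT assay, with a stated time of 72 h; on this read-out lower numbers stand for stronger inhibition and higher numbers for weaker inhibition. Compound 2 `COc1cccc(C(=O)N(C)c2ccc3[nH]c(-c4n[nH]c5ccccc45)cc3n2)c1` gives 9010 nM. Compound 3 `Cc1ccc(S(=O)(=O)N(C)c2ccc3[nH]c(-c4n[nH]c5ccccc45)cc3n2)cc1` gives 9500 nM.

Compound 3 has the highest number of the three, close to compound 2 and separated from compound 1 by a 5.3-fold higher number from compound 1 to compound 3 (0.73 log units; beyond the scatter). Compound 4 `CN(c1ccc2[nH]c(-c3n[nH]c4ccccc34)cc2n1)S(=O)(=O)c1ccc(Cl)cc1` differs from compound 3 by chloro in place of methyl on an aromatic carbon. For the measured compounds named here, no measured step changes a substituent on the sulfonyl-bearing ring; the steps of a 5.1-fold higher number from compound 1 to compound 2 (0.70 log units; beyond the scatter) and a 1.1-fold higher number from compound 2 to compound 3 (0.02 log units; within the scatter) concern the carbonyl and sulfonyl groups themselves and do not bear on this change. The expectation is therefore a step in this assay of about a 1.4-fold lower number from compound 3 to compound 4 (0.13 log units; within the scatter), not beyond the scatter in either direction. Compound 4 is estimated at 7000 nM, within a range of 2500 nM to 20000 nM.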

Compound 4, half-maximal inhibitory concentration: 8350 nM
Beside the measured number, compound 4's estimate is 1.2-fold (0.08 log units) below it; low and high end bracket the measured number.
By their numbers in this assay, from the lowest: compound 1; then compounds 4, 2 and 3 (each within the scatter of the next).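

In this assay, for the compounds shown here, chloro in place of methyl on an aromatic carbon para to a large group gives only a 1.1-fold lower number from compound 3 to compound 4 (0.06 log units; within the scatter), the first reading of a change on the sulfonyl-bearing ring, and that exchange leaves the number within the scatter. Among the other steps, a 1.1-fold lower number from compound 2 to compound 4 (0.03 log units; within the scatter) is also within the scatter, while a 4.7-fold higher number from compound 1 to compound 4 (0.67 log units; beyond the scatter) lies beyond it. Nothing available explains these steps. Still open, from the compounds shown here alone, is whether an amine, a carboxylic acid or a longer chain at this position would move the number, and whether 4-bromophenyl on the sulfonyl would bring it closer to compound 1.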